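A Phenyl Swap in a Level Series

This account rests on a few compounds, and the source may have more. Where it says the series, first, only, none or still open, it means among the compounds named here.

Compound 1 `O=c1oc2ccccc2c2nc3c(ccc4cc[nH]c43)c(-c3cccc(Br)c3)c12` gives 70700 nM in a functional assay on B16-F10 cells (Mus musculus) for cytotoxicity; on this read-out lower numbers stand for stronger inhibition and higher numbers for weaker inhibition. Compound 2 `O=c1oc2ccccc2c2nc3c(ccc4cc[nH]c43)c(-c3ccc(Cl)cc3Cl)c12` gives 70700 nM, and compound 3 `O=c1oc2ccccc2c2nc3c(ccc4cc[nH]c43)c(-c3ccccc3Br)c12` gives 70700 nM. Compound 3 therefore stands level with compounds 1 and 2. Compound 4 `Cc1ccc(-c2c3ccc4cc[nH]c4c3nc3c2c(=O)oc2ccccc23)cc1` differs from compound 3 in one place: 4-methylphenyl in place of 2-bromophenyl on an aromatic carbon. There, 4-methylphenyl stands in place of 2-bromophenyl on an aromatic carbon, opposite the ring nitrogen.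

Three measured steps, all changing the group at this carbon, bear on the swap: no change at the digits printed from compound 1 to compound 3 (within the scatter), no change at the digits printed from compound 1 to compound 2 (within the scatter) and no change at the digits printed from compound 2 to compound 3 (within the scatter). All three lie within the scatter. For the measured compounds named here, none of the measured compounds carries 4-methylphenyl, however, and each carries halogen on its phenyl ring, so these steps guide the expectation without fully covering the change. No step beyond the scatter is expected in this assay, and the range is left wider toward lower numbers. The expected change is a 1.1-fold lower number from compound 3 to compound 4 (0.06 log units; within the scatter). The estimated value for compound 4 is 62000 nM, with an expected range from 25000 nM to 100000 nM.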

Compound 4, half-maximal inhibitory concentration: 70700 nM
Compound 4: the middle estimate sits 1.1-fold (0.06 log units) below what was measured; the measured number falls inside the stated range.
By their numbers in this assay, from the lowest: compounds 1, 2, 3 and 4 (each within the scatter of the next).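

In this assay, putting 4-methylphenyl in place of 2-bromophenyl gives no change at the digits printed from compound 3 to compound 4 (within the scatter). Against the other two halogen-bearing groups, the same swap gives no change at the digits printed from compound 2 to compound 4 (within the scatter) and no change at the digits printed from compound 1 to compound 4 (within the scatter). Halogen on the phenyl ring at this carbon, opposite the ring nitrogen, is therefore not required to hold the read-out at this level, and no measurement at hand explains why the four compounds stand level.

The compounds shown leave open whether a phenyl ring carrying an amine or a hydroxyl group, or a carboxylic acid or longer alkyl chain in place of the ring, would move the number at this carbon beyond the scatter. They also leave open whether a change to the shared core would move it.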